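The source may hold more compounds than are shown below. What is called first, only, known or untested is meant among the compounds shown, and "the series" means these compounds.

The two measured compounds share an amide core and differ only on the benzylic ring. Compound 1 `CC(C(=O)NCc1ccc(C(C)(C)C)nc1OC1CCCC1)c1ccc(NS(C)(=O)=O)c(F)c1` carries a cyclopentyloxy-bearing pyridine and gives 1.5 nM in an assay on cells for antagonist activity at transient receptor potential cation channel subfamily V member 1 (Homo sapiens), read by FLIPR and calcium flux, with a stated time of 6 min; on this read-out lower numbers stand for stronger inhibition and higher numbers for weaker inhibition. Compound 2 `CC(C(=O)NCc1ccc(C(C)(C)C)cc1N1CCCCC1)c1ccc(NS(C)(=O)=O)c(F)c1` carries a piperidin-1-yl group on a carbon ring and gives 1.9 nM in this assay; its number and that of compound 1 lie within the usual scatter of each other, so neither can be called the stronger of the pair. Compound 3 `CCCCOc1cc(C(C)(C)C)ccc1CNC(=O)C(C)c1ccc(NS(C)(=O)=O)c(F)c1` has not been measured in this assay. The change from compound 2 is butoxy in place of piperidin-1-yl on an aromatic carbon. Among the measured compounds shown here, no measured pair shows this kind of exchange, so the expectation rests on the closeness of compound 1 and compound 2 alone, and the step from compound 2 to compound 3 is expected to be small, if anything a slight weakening, a 1.6-fold higher number from compound 2 to compound 3 (0.20 log units; within the scatter). Compound 3 is therefore estimated at 3 nM, with a likely range from 1 nM to 10 nM.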

Compound 3, inhibition constant: 1.4 nM
Compound 3: the middle estimate sits 2.1-fold (0.33 log units) above what was measured; the range from low to high includes it.
By their numbers in this assay, from the lowest: compounds 3, 1 and 2 (each within the scatter of the next).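

In this assay, butoxy in place of piperidin-1-yl, on an aromatic carbon ortho to a large group and meta to a tert-butyl group, gives a 1.4-fold lower number from compound 2 to compound 3 (0.13 log units; within the scatter) and so leaves no readable difference. Among the compounds shown here, this is the first direct exchange at this position, and it shows that an open chain bound through oxygen and a six-membered non-aromatic ring bound through nitrogen cannot be told apart here. The data offer no independent measurement that would account for this closeness.

The compounds shown leave open whether the position would tolerate a much smaller group such as methoxy, a longer chain such as octyloxy, or a carboxylic acid. They also leave open whether the same exchange would read alike on the core of compound 1.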